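The compounds below may be only part of what the source reports. "The series", "measured", "known", "first", "only" and "open" are said of these compounds alone.

Measured so far:

compound 1, `Cc1cccc(-n2nncc2CN2C(=O)C3(C(C#N)=C(N)Oc4c3c3nc5ccccc5nc3c3ccccc43)c3ccccc32)c1`: 39600 nM
compound 2, `N#CC1=C(N)Oc2c(N)cc3nc4ccccc4nc3c2C12C(=O)N(Cc1cnnn1-c1ccccc1Cl)c1ccccc12`: 29800 nM

In a functional assay on A549 cells (Homo sapiens) for antiproliferative activity, read by MTT assay, with a stated time of 48 h (on this read-out lower numbers stand for stronger inhibition and higher numbers for weaker inhibition), compound 1 gives 39600 nM and compound 2 gives 29800 nM. Compound 2 gives the smaller of the two numbers, but the gap to compound 1 lies within the scatter, so the two cannot be separated on these data.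

Compound 3, `N#CC1=C(N)Oc2c(N)cc3nc4ccccc4nc3c2C12C(=O)N(Cc1cnnn1-c1c(F)cccc1F)c1ccccc12`, has not yet been measured. Against compound 2 the change is 2,6-difluorophenyl in place of 2-chlorophenyl on an aromatic nitrogen; the shared core is untouched.

Among the measured compounds shown here, no pair of measured compounds differs only in this group, so nothing here shows what such a change does in this assay. The expectation is therefore a step of no size beyond the scatter in either direction. Compound 3 is expected to give 28000 nM, with a range from 12000 nM to 65000 nM, which means an estimated step of a 1.1-fold lower number from compound 2 to compound 3 (0.03 log units; within the scatter).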

Compound 3, half-maximal inhibitory concentration: > 50000 nM
Compound 3: a limit, no number; the forecaster's own chance of this, stated with the estimate: 5%; at least 1.7-fold (0.25 log units) between middle value and limit.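

In this assay compound 3 gives > 50000 nM, which is a limit of the assay and not a number. Among the compounds shown here, this is the first pair that differs only in the group on the aromatic nitrogen, and the change to 2,6-difluorophenyl gives an at least 1.6-fold higher number from compound 2 to compound 3 (0.22 log units; that floor lies within the scatter), so it brings no gain, while the floor alone shows no loss beyond the scatter. The true size of the step cannot be read, since only its floor is available: the limit of > 50000 nM in this assay, at which 1 of the 3 values shown sits.

As far as these compounds go, it remains open whether this position responds at all to the nature of its group. An unsubstituted phenyl, a phenyl carrying a carboxylic acid or an amine, or a simple alkyl chain on the same nitrogen could test this, ideally with values that fall clear of the limit.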